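Ethyl to isopropyl on the shared core

The source may report more compounds than this note shows. Statements on the series, on what has been measured and on what is new or still open speak of the compounds shown alone.

Values in a functional assay on A549 cells (Homo sapiens) for antiproliferative activity, read by MTT assay, with a stated time of 48 h (on this read-out lower numbers stand for stronger inhibition of growth and higher numbers for weaker inhibition of growth), so far
Compound 1 `Cc1ccc(-c2cnc(N(Cc3ccc(C(=O)NO)cc3)CC(C)C)s2)cc1` (20400 nM)
Compound 2 `CCN(Cc1ccc(C(=O)NO)cc1)c1ncc(-c2ccc(C)cc2)s1` (2700 nM)
Compound 3 `Cc1ccc(-c2cnc(N(Cc3ccc(C(=O)NO)cc3)C(C)C)s2)cc1` (not yet measured)

Compound 2 holds the lower of the two numbers. Compound 3 differs from it by ethyl to isopropyl (methyl in place of hydrogen on a saturated chain carbon bound to a nitrogen on an aromatic ring and a saturated chain carbon), which is methyl in place of hydrogen on a saturated chain carbon bound to a nitrogen on an aromatic ring and a saturated chain carbon. Within the data shown here, the one measured step that bears on this changes a group at a similar place (a 7.6-fold lower number from compound 1 to compound 2 (0.88 log units; beyond the scatter)), with the smaller group giving the lower number. A smaller rise than that is therefore expected in this assay (a 2.2-fold higher number from compound 2 to compound 3 (0.35 log units; beyond the scatter)). For compound 3 the estimated value is 6000 nM (range 2500 nM to 15000 nM).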

Compound 3, concentration for 50% growth inhibition: 3830 nM
Beside the measured number, compound 3's estimate is 1.6-fold (0.19 log units) above it, within the range that was stated.
By their numbers in this assay, from the lowest: compounds 2 and 3 (each within the scatter of the next); then compound 1.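

In this assay, ethyl to isopropyl gives a 1.4-fold higher number from compound 2 to compound 3 (0.15 log units; within the scatter), so adding this methyl on the saturated chain carbon makes no difference that can be told from scatter. Isobutyl stands apart, with a 5.3-fold lower number from compound 1 to compound 3 (0.73 log units; beyond the scatter), which shows that this position tolerates isopropyl but that compound 1 loses out among these three groups. Nothing here explains why these groups compare as they do. On these data alone, it remains open how a ring such as cyclopropyl, or a chain ending in an amine, would fare on this nitrogen.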